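A few compounds are considered here, and "the series" means these few. Any claim that something is new, unique, unknown or untested is made for them only; others in the source may bear on it.

Compound 1 `CCCOC(=O)C1=C(C)NC(=O)NC1c1cccs1`: 32%
Compound 2 `CCCOC(=O)C1=C(C)NC(=O)NC1c1ccsc1`: 6%
Compound 3 `CCCOC(=O)C1=C(C)N(C)C(=O)NC1c1ccsc1`: 11%

All three compounds were tested in an assay on membranes from HeLa cells for displacement of a labelled ligand from adenosine receptor A3 (Homo sapiens), read by scintillation counting, with a stated time of 180 min, tested at 1 uM; on this read-out lower numbers stand for less inhibition and higher numbers for more inhibition at the one concentration tested (going by the name of the read-out). Compound 2 has the lowest of the three numbers. The step of a number 26 percentage points lower from compound 1 to compound 2 (beyond the scatter) lies beyond the scatter, whereas the step of a number 5 percentage points higher from compound 2 to compound 3 (within the scatter) lies within it, so compound 2 and compound 3 cannot be told apart on these numbers.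

Compound 4 `CCC(C)OC(=O)C1=C(C)NC(=O)NC1c1ccsc1` differs from compound 2 by methyl in place of hydrogen on a saturated chain carbon bound to an oxygen next to a carbonyl group and a saturated chain carbon. Among the compounds with values here, neither measured step touches this part of the molecule: the one step concerns the thiophene attachment, the other a methyl on a ring nitrogen. Within the data shown here, the change from compound 2 to compound 4 therefore has no direct precedent among the measured compounds. Among the measured compounds shown here, the only two steps seen are one of modest size and one within the scatter, and nothing among them suggests that lengthening the ester chain should move the number far. The step of a number 3 percentage points higher from compound 2 to compound 4 (within the scatter) in this assay is expected to stay within the scatter. Compound 4 is estimated at 9%, with a range from 0% to 25%.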

Compound 4, a percentage reported as inhibition, at one concentration (the size of the read-out at that concentration, not a potency): 7%
Estimate against measurement, compound 4: 2 percentage points above; low and high end bracket the measured number.
By their numbers in this assay, from the lowest: compounds 2, 4 and 3 (each within the scatter of the next); then compound 1.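

The exchange of propyl for sec-butyl, the first change shown at the saturated chain carbon bound to an oxygen, gives a number 1 percentage points higher from compound 2 to compound 4 (within the scatter) in this assay. This extra methyl therefore leaves no readable mark on the number, and the ester chain is the second place, after the amide-type nitrogen in the ring, where a single added methyl stays within the scatter on this thiophen-3-yl compound. Nothing shown here bears on the reason for this result.

Going by these compounds, because compound 2 already stands at a low number, the same methyl remains untested on the thiophen-2-yl compound, where compound 1 gives 32% and a loss could be seen more readily. On these data alone, whether a longer chain such as hexyl, or a carboxylic acid in place of the ester, would move the number also stays open.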